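Aryl variation at the imine carbon: cytotoxicity notes

The source may report more compounds than this note shows. Statements on the series, on what has been measured and on what is new or still open speak of the compounds shown alone.

Measured so far in a functional assay on RAW264.7 cells (Mus musculus) for cytotoxicity, read by MTT assay, with a stated time of 48 h, tested at 100 uM; on this read-out lower numbers stand for a weaker effect and higher numbers for a stronger effect at the one concentration tested:
compound 1, `CS(=O)(=O)c1ccc(Cc2nnc3n2N=C(c2cc(Cl)sc2S(N)(=O)=O)CS3)cc1`, 35.2%
compound 2, `CS(=O)(=O)c1ccc(Cc2nnc3n2N=C(c2ccc(Cl)cc2Cl)CS3)cc1`, 31%
compound 3, `Cc1ccc(C2=Nn3c(Cc4ccc(S(C)(=O)=O)cc4)nnc3SC2)cc1`, 38.5%

The three numbers lie close together. Compound 3 is not separated from compound 1 or from compound 2, since a number 3.3 percentage points higher from compound 1 to compound 3 (within the scatter) and a number 7.5 percentage points higher from compound 2 to compound 3 (within the scatter) are both within the scatter, as is a number 4.2 percentage points lower from compound 1 to compound 2 (within the scatter). Across three different aryl groups on the carbon with a double bond to nitrogen, this assay therefore shows no step that can be told from repeat variation.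

Compound 4, `CS(=O)(=O)c1ccc(Cc2nnc3n2N=C(c2ccc(O)c(C(N)=O)c2)CS3)cc1`, is not yet measured. It differs from compound 3 in one place: 3-carbamoyl-4-hydroxyphenyl in place of 4-methylphenyl on a carbon with a double bond to nitrogen. For the measured compounds named here, the steps that bear on this change are those in which the same position was varied, namely a number 3.3 percentage points higher from compound 1 to compound 3 (within the scatter) and a number 7.5 percentage points higher from compound 2 to compound 3 (within the scatter), and neither moved beyond the scatter. With no shown step at this position leaving the scatter, no step beyond the scatter is expected for compound 4 either, in either direction. For compound 4 the expected step is a number 2.5 percentage points lower from compound 3 to compound 4 (within the scatter), and the estimate is 36%, with a range from 24% to 50%.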

Compound 4, a percentage reported as activity, at one concentration (the size of the read-out at that concentration, not a potency): 37.1%
Beside the measured number, compound 4's estimate is 1.1 percentage points below it; the measured number falls inside the stated range.
By their numbers in this assay, from the lowest: compounds 2, 1, 4 and 3 (each within the scatter of the next).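

In this assay, the 3-carbamoyl-4-hydroxyphenyl group brings hydrogen-bond donors and acceptors where 4-methylphenyl has none, yet the change gives a number 1.4 percentage points lower from compound 3 to compound 4 (within the scatter). For the compounds shown here, the other two replacements at this position give a number 6.1 percentage points higher from compound 2 to compound 4 (within the scatter) and a number 1.9 percentage points higher from compound 1 to compound 4 (within the scatter), so a fourth aryl group, now with a carbamoyl and a hydroxyl substituent, still shows no step on the carbon with a double bond to nitrogen that can be told from repeat variation. No measured evidence is available to explain this flat read-out.

On these data alone, all four compounds carry an aromatic ring at this position, so the effect of an amine, a carboxylic acid or a longer alkyl chain there remains open. Also open, as far as these compounds go, is whether a full concentration series would separate compounds that a single concentration does not.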